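The compounds below may be only part of what the source reports. "The series", "measured", "known", "first", "only" and "open" are said of these compounds alone.

Of the compounds shown here, three measured so far share one core and differ only in the groups on their outer rings. In a functional assay on NCI-H460 cells (Homo sapiens) for inhibition, read by CCK-8 assay, with a stated time of 48 h (a higher number here means a weaker inhibitor, a lower number a stronger inhibitor), compound 1 `Cc1ccc(NC(=S)NC(=O)c2cn(-c3ccccc3)nc2-c2ccc(F)cc2)cc1` gives 2980 nM, compound 2 `COc1ccc(NC(=S)NC(=O)c2cn(-c3ccccc3)nc2-c2ccc(OC)cc2)cc1` gives 2570 nM, and compound 3 `COc1ccc(-c2nn(-c3ccccc3)cc2C(=O)NC(=S)Nc2ccc(F)cc2)cc1` gives 3050 nM. Compound 3 has the highest of the three numbers, yet all three lie within the scatter of one another, so no order among them can be read. Compound 4 `O=C(NC(=S)Nc1ccc(F)cc1)c1cn(-c2ccccc2)nc1-c1ccc(F)cc1` carries fluoro in place of methoxy on an aromatic carbon. For the measured compounds named here, the only measured step with this same exchange of groups, a 1.2-fold higher number from compound 2 to compound 3 (0.07 log units; within the scatter), stayed within the scatter; no step at the place of this change in compound 4 has been measured. The step from compound 3 to compound 4 is therefore expected to be small, a 1.0-fold lower number from compound 3 to compound 4 (0.01 log units; within the scatter). Compound 4 is estimated at 3000 nM, with a range from 1700 nM to 5500 nM.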

Compound 4, half-maximal inhibitory concentration: 3240 nM
For compound 4 the middle estimate is 1.1-fold (0.03 log units) below the measured one; measured number inside the range.
By their numbers in this assay, from the lowest: compounds 2, 1, 3 and 4 (each within the scatter of the next).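

At the 4-methoxyphenyl position, fluoro in place of methoxy leaves the number in this assay within the scatter (a 1.1-fold higher number from compound 3 to compound 4 (0.03 log units; within the scatter)), so this exchange now proves flat on a second outer ring as well as in the earlier step. On the other outer ring, fluoro in place of methyl is also within the scatter (a 1.1-fold higher number from compound 1 to compound 4 (0.04 log units; within the scatter)). Nothing given here offers an explanation for these flat steps. The compounds shown carry only methoxy, methyl and fluoro at these places. From the compounds shown here alone, whether an amine, a carboxylic acid or a longer chain there would move the number remains open.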